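Trimming a Methyl From a Weak Antiproliferative Ester

This account rests on a few compounds, and the source may have more. Where it says the series, first, only, none or still open, it means among the compounds named here.

Compound 1, `CCOC(=O)C(c1cccc(OC)c1)C(c1ccc(O)cc1)c1ccc(O)cc1`: 85100 nM
Compound 2, `CCOC(=O)C(c1ccc(C)cc1)C(c1ccc(O)cc1)c1ccc(O)cc1`: 78700 nM

Both compounds were tested in a functional assay on MCF7 cells (Homo sapiens) for antiproliferative activity, with a stated time of 72 h; a higher number here means a weaker inhibitor, a lower number a stronger inhibitor. Compound 1 gives 85100 nM and compound 2 gives 78700 nM, so compound 2 stands beside compound 1, the two numbers lying within the scatter of each other. Going by the values given here, the single measured step, a 1.1-fold lower number from compound 1 to compound 2 (0.03 log units; within the scatter), exchanges one aryl group for another on the same chain carbon and stays within the scatter.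

Compound 3, `CCOC(=O)C(c1ccccc1)C(c1ccc(O)cc1)c1ccc(O)cc1`, differs from compound 2 by hydrogen in place of methyl on an aromatic carbon. Among the compounds with values here, only that one measured step bears on this change, and it bears only loosely, since it swaps two aryl groups rather than removing a methyl; still, it suggests that changes at this aryl group move this assay little. No step beyond the scatter is expected. Compound 3 is therefore expected to give 80000 nM, with a range of 40000 nM to 160000 nM. That estimate means an expected step of a 1.0-fold higher number from compound 2 to compound 3 (0.01 log units; within the scatter).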

Compound 3, half-maximal inhibitory concentration: 80600 nM
The estimate for compound 3 lay 1.0-fold (0.00 log units) below the measured number; the range from low to high includes it.
By their numbers in this assay, from the lowest: compounds 2, 3 and 1 (each within the scatter of the next).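

With compound 3, the aryl group finally carries no substituent, so methyl and methoxy can each be compared with plain hydrogen rather than only with each other. In this assay, removing the methyl from the aromatic carbon para to a large group gives a 1.0-fold higher number from compound 2 to compound 3 (0.01 log units; within the scatter) and removing the methoxy gives a 1.1-fold lower number from compound 1 to compound 3 (0.02 log units; within the scatter), so neither group separates from hydrogen at its place on the ring. No further measurement here bears on this result.

From the compounds shown here alone, all three compounds carry only small neutral groups or none on this ring, so it remains open whether an amine or a carboxylic acid there would shift the number beyond the scatter. The shared core's ethyl ester and two phenol groups also stay constant, leaving their part in this weak activity unknown.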